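The source may report more compounds than this note shows. Statements on the series, on what has been measured and on what is new or still open speak of the compounds shown alone.

Measured so far in an in vitro assay on HEK293 cells for displacement of a labelled ligand from adenosine receptor A2b (Homo sapiens) (on this read-out lower numbers stand for stronger inhibition and higher numbers for weaker inhibition), are two numbers and one limit. Compound 1 `CCCn1c(=O)c2nc(-c3cnn(Cc4cc(Cl)ccc4Cl)c3)[nH]c2n(CCC)c1=O` gives 29 nM. Compound 2 `CCCn1c(=O)c2nc(-c3cnn(Cc4cc(C(F)(F)F)ccc4Cl)c3)[nH]c2n(CCC)c1=O` gives 22 nM. Compound 3 `CCCn1c(=O)c2c(nc(-n3cccn3)n2Cc2ccccc2)n(CCC)c1=O` gives only a limit of this assay, > 5800 nM, which counts as no number (the limit of > 5800 nM in this assay, at which 1 of the 3 values shown sits).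

Compound 2 therefore holds the lower of the two numbers, and the step of a 1.3-fold lower number from compound 1 to compound 2 (0.12 log units; within the scatter) shows that compound 1 sits within the scatter of it. Compound 4 `CCCn1c(=O)c2nc(-c3cnn(Cc4cccc(Cl)c4)c3)[nH]c2n(CCC)c1=O` differs from compound 2 by 3-chlorophenyl in place of 2-chloro-5-(trifluoromethyl)phenyl on a saturated chain carbon bound to an aromatic nitrogen. For the measured compounds named here, the one measured step, a 1.3-fold lower number from compound 1 to compound 2 (0.12 log units; within the scatter), exchanged a single group on this ring and moved little; no measured step removes a group from it. Compound 4 is therefore expected to land near compound 2, a step of a 1.8-fold higher number from compound 2 to compound 4 (0.26 log units; within the scatter), estimated at 40 nM with a range from 12 nM to 150 nM.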

Compound 4, inhibition constant: 18 nM
Estimate against measurement, compound 4: 2.2-fold (0.35 log units) above; measured number inside the range.
By their numbers in this assay, from the lowest: compounds 4, 2 and 1 (each within the scatter of the next). At a limit, above all of these: compound 3.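

Exchanging 2-chloro-5-(trifluoromethyl)phenyl for 3-chlorophenyl in this assay gives a 1.2-fold lower number from compound 2 to compound 4 (0.09 log units; within the scatter) and so leaves the number in the same range, even though the group is smaller. Hydrogen in place of chloro on an aromatic carbon gives a 1.6-fold lower number from compound 1 to compound 4 (0.21 log units; within the scatter) and is the first measured step that removes a group from this ring, yet it too moves little. Nothing shown here bears on why these changes move the number so little.

From the compounds shown here alone, whether the phenyl ring without any chloro would stay in this range remains open. So does the outcome of an amine or a carboxylic acid on this ring.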